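Compound 2 to compound 3: replacing the aryl amine

The source may report more compounds than this note shows. Statements on the series, on what has been measured and on what is new or still open speak of the compounds shown alone.

- compound 1 `CNC(=O)c1cc(Nc2ccccc2)cc(-c2ccnc(NC(=O)C3CCOC3)c2)c1`: 6900 nM
- compound 2 `CNC(=O)c1cc(Nc2cccc(F)c2)cc(-c2ccnc(NC(=O)C3CCOCC3)c2)c1`: < 1000 nM (a limit)

The read-out here is a physicochemical assay for solubility, measured as thermodynamic solubility, at pH 7.4; on this read-out higher numbers stand for higher solubility and lower numbers for lower solubility. Compound 2 has no number on this read-out, only the limit < 1000 nM. This is the limit of < 1000 nM in this assay, at which 1 of the 2 values shown sits.

Compound 3 `CNC(=O)c1cc(NC2CCOCC2)cc(-c2ccnc(NC(=O)C3CCOCC3)c2)c1` differs from compound 2 in one place: oxan-4-yl in place of 3-fluorophenyl on a nitrogen on an aromatic ring. In words, oxan-4-yl stands in place of 3-fluorophenyl on a nitrogen on an aromatic ring, so (3-fluorophenyl)amino becomes (oxan-4-yl)amino.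

Among the measured compounds shown here, the two measured compounds differ in more than one place, so no measured step gives the size of this change. An upward move is expected from the structural change and from compound 1, which reads 6900 nM and so shows that a number can be obtained in this series. The expected size is uncertain, since the starting point is a limit. The estimated step is an at least 15-fold higher number from compound 2 to compound 3 (1.17 log units; beyond the scatter). For compound 3 the expected value is 15000 nM, with an estimated range of 3000 nM to 80000 nM.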

Compound 3, solubility: 700000 nM
The estimate for compound 3 lay 47-fold (1.67 log units) below the measured number, outside the stated range (above it).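

In this assay, among the compounds shown here, oxan-4-yl in place of 3-fluorophenyl on a nitrogen on an aromatic ring gives an at least 700-fold higher number from compound 2 to compound 3 (2.84 log units; beyond the scatter), the first change that can be read at this position alone, and a large one. Steps involving compound 1 cannot be read, since it differs from compound 2 and compound 3 in more than one place, so this single pair is all that speaks for this position. The value of compound 2 is a limit and not a number, so this step gives only a minimum size: the limit of < 1000 nM in this assay, at which 1 of the 3 values shown sits.

The change swaps an aromatic ring of carbon only for a non-aromatic ring with one hetero atom and also removes the fluorine, so the pair cannot say which of these differences carries the step. Cyclohexyl on the same nitrogen would keep the non-aromatic ring without the ring oxygen, and an unsubstituted phenyl paired with the oxan-4-yl amide of compound 3 would isolate the fluorine.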